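The source may report more compounds than this note shows. Statements on the series, on what has been measured and on what is new or still open speak of the compounds shown alone.

Three compounds of this series have numbers in a functional assay on HeLa cells (Homo sapiens) for antiproliferative activity, read by sulforhodamine B assay, with a stated time of 48 h; on this read-out lower numbers stand for stronger inhibition of growth and higher numbers for weaker inhibition of growth. Compound 1 `COc1cc(-c2cc(CO[C@@H]3O[C@H](CSc4ncn[nH]4)[C@H]4OC5(CCCC5)O[C@@H]34)on2)cc(OC)c1OC` gives 67000 nM, compound 2 `O=[N+]([O-])c1ccc(-c2nc(CO[C@@H]3O[C@H](CO)[C@H]4OC5(CCCC5)O[C@@H]34)no2)cc1` gives 15000 nM, and compound 3 `CC1(C)O[C@H]2[C@H](OCc3noc(-c4ccc([N+](=O)[O-])cc4)n3)O[C@H](CSc3ncn[nH]3)[C@H]2O1` gives 89000 nM. On these numbers compound 2 stands lowest, with compound 1 nearest and compound 3 furthest, both gaps beyond the scatter. Compound 4 `O=[N+]([O-])c1ccc(-c2nc(CO[C@@H]3O[C@H](CSc4ncn[nH]4)[C@H]4OC5(CCCC5)O[C@@H]34)no2)cc1` is not yet measured; it differs from compound 2 by (1H-1,2,4-triazol-5-yl)sulfanyl in place of hydroxy on a saturated chain carbon bound to a saturated ring carbon. Going by the values given here, no two measured compounds differ in one place, so this step has no measured counterpart. Compound 3 carries the same entering group on its own core and gives 89000 nM, and compound 1 carries it as well and gives 67000 nM, so a rise toward those numbers is expected. The expected step is a 3.3-fold higher number from compound 2 to compound 4 (0.52 log units; beyond the scatter), a weakening beyond the scatter. For compound 4 the estimate is 50000 nM, within 15000 nM to 150000 nM.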

Compound 4, concentration for 50% growth inhibition: 20000 nM
Estimate against measurement, compound 4: 2.5-fold (0.40 log units) above; the measured number falls inside the stated range.
By their numbers in this assay, from the lowest: compounds 2 and 4 (each within the scatter of the next); then compounds 1 and 3 (each within the scatter of the next).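

In this assay the exchange at this position gives a 1.3-fold higher number from compound 2 to compound 4 (0.12 log units; within the scatter) and so leaves the number unchanged within the scatter, even though the entering group brings a five-membered aromatic ring and more heavy atoms. Going by these compounds alone, this is the first one-place comparison, and it shows that a saturated chain carbon bound to a saturated ring carbon accepts (1H-1,2,4-triazol-5-yl)sulfanyl as readily as hydroxy on this core. No measurement at hand accounts for this result.

On these data alone, whether an amine, a carboxylic acid or a longer chain would be accepted here remains open, as does whether the same exchange gives the same result on the core of compound 3.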